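Amide Series Carrying a Larger Amine on the Carbonyl

The source may report more compounds than this note shows. Statements on the series, on what has been measured and on what is new or still open speak of the compounds shown alone.

Compound 1: `CN(C)S(=O)(=O)c1ccccc1Nc1cc(-c2ccc3ccn(C)c3c2)c2nccnc2c1` — 94 nM
Compound 2: `Cn1ccc2ccc(-c3cc(Nc4ccccc4S(=O)(=O)NCC4CCOCC4)cc4nccnc34)cc21` — 26 nM
Compound 3: `CN(C)C(=O)c1ccncc1Nc1cc(-c2ccc3ccn(C)c3c2)c2nccnc2c1` — 499 nM

In an assay for inhibition of 6-phosphofructo-2-kinase/fructose-2,6-bisphosphatase 3 (Homo sapiens), read by ADP-Glo, with a stated time of 2 h (on this read-out higher numbers stand for weaker inhibition and lower numbers for stronger inhibition), compound 3 gives the highest of the three numbers, with compound 1 nearest and compound 2 furthest away, both steps beyond the scatter. Compound 4, `CC(=O)N1CCOC(CNC(=O)c2ccncc2Nc2cc(-c3ccc4ccn(C)c4c3)c3nccnc3c2)C1`, has not yet been measured in this assay. It differs from compound 3 by ((4-acetylmorpholin-2-yl)methyl)amino in place of dimethylamino on a carbonyl carbon.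

Within the data shown here, the only measured step that bears on this is the one from compound 1 to compound 2, where dimethylamino on a sulfonyl sulfur gave way to ((oxan-4-yl)methyl)amino: a 3.6-fold lower number from compound 1 to compound 2 (0.56 log units; beyond the scatter). The change from compound 3 to compound 4 likewise exchanges dimethylamino for a larger amino group carrying a six-membered non-aromatic ring, though on a carbonyl carbon rather than a sulfonyl sulfur, and the entering group here is ((4-acetylmorpholin-2-yl)methyl)amino. On that one precedent a modest lowering of the number is expected, with caution because of a 3.6-fold lower number from compound 1 to compound 2 (0.56 log units; beyond the scatter) resting on a different attachment. The expected step is a 2.9-fold lower number from compound 3 to compound 4 (0.47 log units; beyond the scatter). Compound 4 is therefore estimated at 170 nM, within a range of 60 nM to 500 nM.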

Compound 4, half-maximal inhibitory concentration: 93 nM
Estimate against measurement, compound 4: 1.8-fold (0.26 log units) above; the measured number falls inside the stated range.
By their numbers in this assay, from the lowest: compound 2; then compounds 4 and 1 (each within the scatter of the next); then compound 3.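

In this assay, the result shows that the carbonyl carbon accepts ((4-acetylmorpholin-2-yl)methyl)amino, a much larger group than dimethylamino, with a 5.4-fold lower number from compound 3 to compound 4 (0.73 log units; beyond the scatter) as the outcome. The earlier compounds had shown a lowering on exchange of dimethylamino only on a sulfonyl sulfur, as a 3.6-fold lower number from compound 1 to compound 2 (0.56 log units; beyond the scatter) records, and the same direction now appears on a carbonyl carbon, with one pair for each attachment. Nothing at hand explains the lowering at this position.

The entering group brings a ring, an acetyl group and an amide hydrogen together, and the compounds shown leave open which of these accounts for the step. Also open, going by these compounds, is how a simple methylamino group, or the morpholine ring with a free ring amine in place of the acetyl, would read on this carbonyl carbon.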